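The source may hold more compounds than are shown below. What is called first, only, known or untested is meant among the compounds shown, and "the series" means these compounds.

Measured so far:
compound 1 `CCCS(=O)(=O)N1CCC(CNC(=O)c2c(F)cccc2F)(C(=O)N2CCOCC2)CC1` — > 22 10^-6 cm/s
compound 2 `CCCS(=O)(=O)N1CCC(CNC(=O)c2ccccc2OC(F)(F)F)(C(=O)N2CCOCC2)CC1` — > 22 10^-6 cm/s

Where compound 1 stands in an ADME assay on Caco-2 cells (Homo sapiens) for permeability (on this read-out lower numbers stand for lower permeability and higher numbers for higher permeability), is known only as a limit of the assay, not as a number: compound 1 gives > 22 10^-6 cm/s. Compound 2 `CCCS(=O)(=O)N1CCC(CNC(=O)c2ccccc2OC(F)(F)F)(C(=O)N2CCOCC2)CC1` is likewise reported only as a limit, > 22 10^-6 cm/s. Both values sit at the limit of > 22 10^-6 cm/s in this assay, at which 2 of the 2 values shown sit, so the step that the two limits leave unreadable from compound 1 to compound 2 cannot be given a size; all that can be said is that neither compound falls short of the limit.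

Compound 3 `CCCS(=O)(=O)N1CCC(CNC(=O)c2ccccc2Cl)(C(=O)N2CCOCC2)CC1` differs from compound 1 in one place: 2-chlorophenyl in place of 2,6-difluorophenyl on a carbonyl carbon. Going by the values given here, the only measured step, from compound 1 to compound 2, also exchanges the group on this carbonyl carbon and leaves both compounds at the same limit, so it offers no readable size and no direction. Among the compounds with values here, no measured step involves the 2-chlorophenyl group itself. The expectation for a step that the limit leaves unreadable from compound 1 to compound 3 is therefore no step beyond the scatter, with compound 3 most likely reported again as a limit rather than a number. Compound 3 is estimated at 30 10^-6 cm/s, within a range of 15 10^-6 cm/s to 60 10^-6 cm/s.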

Compound 3, apparent permeability: > 22 10^-6 cm/s
Compound 3: no number, only a limit (the forecaster's own chance of this, stated with the estimate: 75%); the middle value lies beyond the limit too.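

In this assay compound 3 gives > 22 10^-6 cm/s, again a limit and not a number, so no step among compound 1, compound 2 and compound 3 can be read, because all three share one limit: the limit of > 22 10^-6 cm/s in this assay, at which 3 of the 3 values shown sit.

The compounds shown leave open how far their values lie apart, and whether exchanging the group on the carbonyl carbon moves this read-out at all.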